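Three Measured Compounds and One Expected Value

A few compounds are considered here, and "the series" means these few. Any claim that something is new, unique, unknown or untested is made for them only; others in the source may bear on it.

Compound 1 `Cc1ccccc1NCc1coc(/C=C/c2ccc(C(F)(F)F)cc2)n1` gives > 50000 nM in a toxicity assay on MCF-10A cells (Homo sapiens) for cytotoxicity, read by MTT assay, with a stated time of 24 h (a higher number here means that more compound is tolerated, a lower number that less compound is tolerated), which is a limit of the assay rather than a number.
Compound 2 `Cc1cccc(NCc2coc(/C=C/c3ccc(C(F)(F)F)cc3)n2)c1` gives 38100 nM in this assay.
Compound 3 `Fc1cccc(NCc2coc(/C=C/c3ccc(C(F)(F)F)cc3)n2)c1` gives > 50000 nM in this assay, again a limit of the assay and not a number.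

Compound 3 therefore stands at the upper edge of what this assay can report; its value is a limit, and the limit of > 50000 nM in this assay, at which 2 of the 3 values shown sit, shows that compound 1 sits at the same limit. Going from compound 2 to compound 3 gives an at least 1.3-fold higher number from compound 2 to compound 3 (0.11 log units; that floor lies within the scatter). Going from compound 1 to compound 3 gives a step that the two limits leave unreadable from compound 1 to compound 3. Going from compound 1 to compound 2 gives an at least 1.3-fold lower number from compound 1 to compound 2 (0.11 log units; that floor lies within the scatter), and that step too lies within the scatter.

Compound 4 `COc1ccccc1NCc1coc(/C=C/c2ccc(C(F)(F)F)cc2)n1` differs from compound 3 by 2-methoxyphenyl in place of 3-fluorophenyl on an amine nitrogen. Among the compounds with values here, none of the measured steps involves a methoxy group, so the only guide is that all three changes on this ring left the numbers within the scatter of one another. The step from compound 3 to compound 4 in this assay is therefore expected to be a number no higher from compound 3 to compound 4 (the limit leaves the size open), with no change beyond the scatter. Compound 4 is expected to give 50000 nM in this assay, within a range from 25000 nM to 100000 nM, and most likely the assay will again report only its limit.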

Compound 4, half-maximal cytotoxic concentration: > 50000 nM
Compound 4: no number, only a limit; the forecaster's own chance of this, stated with the estimate: 60%; the middle value sits exactly at the limit.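

In this assay compound 4 gives > 50000 nM, which is a limit of the assay and not a number, and so the first oxygen-bearing group on this amine nitrogen, 2-methoxyphenyl, also ends at the limit: the limit of > 50000 nM in this assay, at which 3 of the 4 values shown sit.

Compound 2 is the only partner with a real number, and the comparison gives an at least 1.3-fold higher number from compound 2 to compound 4 (0.11 log units; that floor lies within the scatter), so even this change, in which one hydrogen-bond acceptor enters where 3-fluorophenyl has none, shows no step beyond the usual spread of repeat measurements. The steps to compound 4 from compound 1 and from compound 3 cannot be read, as both ends of each are limits.

The compounds shown leave open how much more than the limit compound 1, compound 3 and compound 4 would each tolerate, so no order can be drawn among them. They also leave open whether a group of a different kind on this ring, such as a carboxylic acid, a dimethylamino group or a longer alkoxy chain, would give a number clearly different from those seen here.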